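This account rests on a few compounds, and the source may have more. Where it says the series, first, only, none or still open, it means among the compounds named here.

Measured in a functional assay on the whole organism with Mus musculus as the target; on this read-out higher numbers stand for an effect only at larger amounts of compound and lower numbers for an effect already at smaller amounts:
- compound 1 `C[C@@H](NCc1ccc(OCc2ccccc2)cc1)C(N)=O`: 23.8 mg/kg
- compound 2 `CNC(=O)[C@@H](C)NCc1ccc(OCc2ccccc2)cc1`: 40.5 mg/kg
- compound 3 `CC[C@@H](NCc1ccc(OCc2ccccc2)cc1)C(N)=O`: 55 mg/kg

Compound 1 cannot be separated from compound 2 on these numbers: a 1.7-fold higher number from compound 1 to compound 2 (0.23 log units; within the scatter). It is separated only from compound 3, whose number is the higher one: a 2.3-fold higher number from compound 1 to compound 3 (0.36 log units; beyond the scatter). The remaining pair gives a 1.4-fold higher number from compound 2 to compound 3 (0.13 log units; within the scatter).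

Compound 4 `C[C@@H](NCc1ccc(OCc2ccccn2)cc1)C(N)=O` differs from compound 1 in one place: pyridin-2-yl in place of phenyl on a saturated chain carbon bound to an oxygen on an aromatic ring. The benzyl group of compound 1 thus becomes (pyridin-2-yl)methyl, while the rest of the molecule stays the same.

Among the compounds with values here, none of the measured steps touches this group, so the series gives no direct precedent for the change. The steps show only how far single changes elsewhere in compound 1 have moved this assay, namely a 1.7-fold higher number from compound 1 to compound 2 (0.23 log units; within the scatter) and a 2.3-fold higher number from compound 1 to compound 3 (0.36 log units; beyond the scatter). On that basis, a step of similar modest size is expected, most likely within the scatter. The data give no direction, and a slight lean toward a higher number is a judgement only.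

The expected step is a 1.4-fold higher number from compound 1 to compound 4 (0.14 log units; within the scatter).

For compound 4 the estimated value is 33 mg/kg, with an expected range from 14 mg/kg to 85 mg/kg.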

Compound 4, dose for half-maximal effect: 172 mg/kg
Compound 4: middle estimate off by 5.2-fold (0.72 log units), on the low side, and the stated range ends below it.
By their numbers in this assay, from the lowest: compounds 1, 2 and 3 (each within the scatter of the next, the first and the last beyond it); then compound 4.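

In this assay, within the data shown here, the exchange of phenyl for pyridin-2-yl on the saturated chain carbon bound to an oxygen on an aromatic ring gives a 7.2-fold higher number from compound 1 to compound 4 (0.86 log units; beyond the scatter) and is the first measured change at this position. Among these compounds, the step is larger than the single changes elsewhere in compound 1, a 1.7-fold higher number from compound 1 to compound 2 (0.23 log units; within the scatter) and a 2.3-fold higher number from compound 1 to compound 3 (0.36 log units; beyond the scatter), so among the places varied in these compounds, this one moves the read-out furthest. Heavy-atom count stays at 6 across the exchange, and the entering ring carries 1 hetero atom and 1 hydrogen-bond acceptor where the leaving ring has none, yet no measurement shown bears on why the step is this large.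

The compounds shown leave open whether the step is tied to this placement of the ring nitrogen, as pyridin-3-yl or pyridin-4-yl on the same carbon would show, and whether a substituted phenyl such as 3-fluorophenyl stays close to compound 1. They also leave open whether pyridin-2-yl brings a step of similar size on the core of compound 2 or compound 3.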